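Extending the Aryl Group on the Shared Core

The compounds below may be only part of what the source reports. "The series", "measured", "known", "first", "only" and "open" are said of these compounds alone.

The measured compounds and their values:
compound 1, `CCc1nc2sccn2c1/C=N/OCc1ccc(Cl)c(Cl)c1`, in an assay on HepG2 cells for agonist activity at nuclear receptor subfamily 1 group I member 3 (Homo sapiens), read by a luciferase reporter, with a stated time of 23 h (a higher number here means that more compound is needed for the effect, a lower number that less compound is needed), compound 1 gives 2600 nM
compound 2, `Clc1ccc(CO/N=C/c2c(-c3cccc4ccccc34)nc3sccn23)cc1Cl`, in this assay compound 2 gives 940 nM
compound 3, `Clc1ccc(CO/N=C/c2c(-c3ccccc3)nc3sccn23)cc1Cl`, in this assay compound 3 gives 580 nM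

Compound 3 has the lowest number of the three. Its nearest neighbour is compound 2, separated by a 1.6-fold lower number from compound 2 to compound 3 (0.21 log units; within the scatter), so these two cannot be told apart. Compound 1 is furthest away: the exchange of ethyl for phenyl gave a 4.5-fold lower number from compound 1 to compound 3 (0.65 log units; beyond the scatter), and the related exchange for naphthalen-1-yl gave a 2.8-fold lower number from compound 1 to compound 2 (0.44 log units; beyond the scatter).

Compound 4, `Clc1ccc(CO/N=C/c2c(-c3ccc(-c4ccccc4)cc3)nc3sccn23)cc1Cl`, is compound 3 with one further change: phenyl in place of hydrogen on an aromatic carbon. Among the compounds with values here, the step that bears on this most directly is the one from compound 2 to compound 3, where a larger aromatic group was replaced by a smaller one and the number moved only within the scatter. Enlarging the aromatic group again, now by attaching a second phenyl, is therefore expected to change little; if anything, the number may drift upward slightly, as compound 2 shows. The expected step is a 1.6-fold higher number from compound 3 to compound 4 (0.19 log units; within the scatter).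

Compound 4 is estimated to give 900 nM in this assay, with a likely range from 300 nM to 2700 nM.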

Compound 4, half-maximal effective concentration: "not active" (no number reported)
No number was reported for compound 4; the estimate stays without a comparison.
By their numbers in this assay, from the lowest: compounds 3 and 2 (each within the scatter of the next); then compound 1.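

In this assay, within the data shown here, compound 4 is reported as "not active" with no number, so no step from compound 3 to compound 4 can be read. The compounds shown leave open how far the added phenyl shifts the number needed for the effect. Nothing given here bears on the reason for this result.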